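Adding an Ethylamino Group to the Core of Compound 1

The source may report more compounds than this note shows. Statements on the series, on what has been measured and on what is new or still open speak of the compounds shown alone.

Compound 1, `COc1nn(C)c2ncnc(NS(=O)(=O)c3cccc(Cl)c3Cl)c12`, gives 63.1 nM.
Compound 2, `COc1nn(CC(N)=O)c2ncnc(NS(=O)(=O)c3cccc(Cl)c3Cl)c12`, gives 501 nM.
Compound 3, `COCCn1nc(OC)c2c(NS(=O)(=O)c3cccc(Cl)c3Cl)ncnc21`, gives 316 nM.

These three compounds were tested in a functional assay on cells for antagonist activity at C-C chemokine receptor type 4 (Homo sapiens), read by GTPgammaS binding; on this read-out higher numbers stand for weaker inhibition and lower numbers for stronger inhibition. Among them compound 1 gives the lowest number, and both of its neighbours sit beyond the usual scatter: a 7.9-fold higher number from compound 1 to compound 2 (0.90 log units; beyond the scatter) and a 5.0-fold higher number from compound 1 to compound 3 (0.70 log units; beyond the scatter). Compound 2 and compound 3 do not separate from each other, since a 1.6-fold lower number from compound 2 to compound 3 (0.20 log units; within the scatter).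

Compound 4, `CCNc1nc(NS(=O)(=O)c2cccc(Cl)c2Cl)c2c(OC)nn(C)c2n1`, has not yet been measured. It differs from compound 1 in one place: ethylamino in place of hydrogen on an aromatic carbon. For the measured compounds named here, every measured step so far changed the group on a saturated chain carbon bound to an aromatic nitrogen, while the change to compound 4 leaves that group as it is in compound 1 and instead adds to an aromatic carbon of the core. Going by the values given here, none of the measured steps therefore bears directly on this change; they only show that the shared core tolerates small groups at its edge with modest losses.

Among the compounds with values here, with no direct precedent, the expectation for compound 4 is a step of a 1.4-fold higher number from compound 1 to compound 4 (0.15 log units; within the scatter) in this assay, which cannot be called a change beyond the scatter with confidence. The estimated value for compound 4 is 90 nM, within a range from 20 nM to 450 nM.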

Compound 4, half-maximal inhibitory concentration: 251 nM
Compound 4: the middle estimate sits 2.8-fold (0.45 log units) below what was measured; low and high end bracket the measured number.
By their numbers in this assay, from the lowest: compound 1; then compounds 4, 3 and 2 (each within the scatter of the next).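

This aromatic carbon of the core, which lies between two ring nitrogen atoms, is the first place shown outside the group on the ring nitrogen, and it does not accept ethylamino without a loss. In this assay, replacing hydrogen there with ethylamino gives a 4.0-fold higher number from compound 1 to compound 4 (0.60 log units; beyond the scatter), which means weaker inhibition, though the step is modest in size. Compound 1 therefore loses activity from a change on this aromatic carbon as well as from the changes on the saturated chain, but nothing shown here explains the loss.

On these data alone, what remains open is whether the loss follows the nitrogen that joins ethylamino to the core or the two-carbon chain beyond it, which a plain amino group, a methoxy group or a longer chain such as butylamino on this aromatic carbon could help separate. Also open, as far as these compounds go, is how ethylamino on this carbon would behave with the carbamoyl of compound 2 or the methoxymethyl of compound 3 in place of the hydrogen on the saturated chain carbon.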